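The source may report more compounds than this note shows. Statements on the series, on what has been measured and on what is new or still open speak of the compounds shown alone.

Measured so far in an assay on isolated protein for inhibition of Alpha glucosidase (Homo sapiens), read by spectrophotometry, with stated times of 15 min and 30 min; a lower number here means a stronger inhibitor, a higher number a weaker inhibitor:

- compound 1 `O=C1NC(=O)/C(=C/c2cc(Cl)ccc2OCN2C(=O)c3ccccc3C2=O)S1` — > 100000 nM; this is a limit of the assay, not a number
- compound 2 `O=C1NC(=O)/C(=C/c2cc([N+](=O)[O-])ccc2OCN2C(=O)c3ccccc3C2=O)S1` — 50500 nM
- compound 3 `O=C1NC(=S)S/C1=C\c1ccc(OCN2C(=O)c3ccccc3C2=O)c([N+](=O)[O-])c1` — 6590 nM

Within the first core, one step is measured. From compound 2 to compound 1 the change is chloro in place of nitro on an aromatic carbon, and it gave an at least 1.9-fold higher number from compound 2 to compound 1 (0.29 log units; that floor lies within the scatter). The size of that step is only a floor, because compound 1 sits at the limit of > 100000 nM in this assay, at which 1 of the 3 values shown sits.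

Compound 3 has the lowest of the two numbers in this assay; compound 2 is its nearest neighbour, and the gap between them is beyond the scatter. How the core of compound 3 differs from the core of compound 2 is not broken down here.

Not yet measured is compound 4 `O=C1NC(=S)S/C1=C\c1ccc(OCN2C(=O)c3ccccc3C2=O)c(Cl)c1`. It differs from compound 3 by chloro in place of nitro on an aromatic carbon. Among the compounds with values here, this is the same kind of change as the one from compound 2 to compound 1, not the same change: in compound 4 the chloro stands ortho to a large group and meta to a group of 8 heavy atoms, whereas in compound 1 it stands meta to a group of 8 heavy atoms and para to a large group.

Set beside an at least 1.9-fold higher number from compound 2 to compound 1 (0.29 log units; that floor lies within the scatter), the expected step is a 3.0-fold higher number from compound 3 to compound 4 (0.48 log units; beyond the scatter); this rests on the single measured occurrence of the change, which itself is only a floor. The estimate for compound 4 in this assay is 20000 nM, expected to fall between 6000 nM and 80000 nM.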

Compound 4, half-maximal inhibitory concentration: 5440 nM
Compound 4: middle estimate off by 3.7-fold (0.57 log units), on the high side; the whole stated range lies above it.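

In this assay, chloro in place of nitro on the core of compound 3 gave a 1.2-fold lower number from compound 3 to compound 4 (0.08 log units; within the scatter), so on this core the two groups cannot be told apart, and the chloro of compound 4 stands ortho to a large group and meta to a group of 8 heavy atoms, a different place from the chloro of compound 1. Set beside the step on the first core, the change can be compared only in part: the same change on two cores in this assay, an at least 1.9-fold higher number (0.29 log units; that floor lies within the scatter) from compound 2 to compound 1 and a 1.2-fold lower number (0.08 log units; within the scatter) from compound 3 to compound 4; the limit leaves it open whether they differ. This shows no clear divergence between the two cores, but it also does not show that the change carries over at the same size, as compound 1 gives a limit of the assay and not a number, and each core offers only one pair: the limit of > 100000 nM in this assay, at which 1 of the 4 values shown sits.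

Left open is whether the closeness of nitro and chloro on the core of compound 3 extends to other groups at that place, such as an amine, a carboxylic acid or a longer chain. Also open, going by these compounds, is whether nitro and chloro placed alike on both cores would give a pair of true numbers on each, which would allow a direct comparison of the step.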